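One Carbon More in the Chain of Compound 3

A few compounds are considered here, and "the series" means these few. Any claim that something is new, unique, unknown or untested is made for them only; others in the source may bear on it.

In a functional assay, read by spectrophotometry (on this read-out higher numbers stand for an effect only at larger amounts of compound and lower numbers for an effect already at smaller amounts), compound 1 `COc1ccc(-c2cc(=O)c3ccc(OCCCCN4CCC(CCO)CC4)cc3o2)cc1` gives 23.2 nM. Compound 2 `COc1ccc(-c2cc(=O)c3ccc(OCCCCCN4CCC(CCO)CC4)cc3o2)cc1` gives 27.9 nM, which stands within the scatter of that number. Compound 3 `COc1ccc(-c2cc(=O)c3ccc(OCCCCCCN4CCC(CCO)CC4)cc3o2)cc1` differs from compound 2 by a single change: (4-(2-hydroxyethyl)piperidin-1-yl)methyl in place of 4-(2-hydroxyethyl)piperidin-1-yl on a saturated chain carbon, five bonds along the chain from an oxygen on an aromatic ring. Going by the values given here, the same swap, made four bonds along the chain from an oxygen on an aromatic ring, is the only measured guide, and it was a 1.2-fold higher number from compound 1 to compound 2 (0.08 log units; within the scatter). One small step is thin evidence, but no shift beyond the scatter is expected in this assay. The expected change is a 1.1-fold higher number from compound 2 to compound 3 (0.03 log units; within the scatter). Compound 3 is estimated at 30 nM, with an expected range from 15 nM to 60 nM.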

Compound 3, half-maximal effective concentration: 34.4 nM
The estimate for compound 3 lay 1.1-fold (0.06 log units) below the measured number, within the range that was stated.
By their numbers in this assay, from the lowest: compounds 1, 2 and 3 (each within the scatter of the next).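

One more carbon at this place, five bonds along the chain from an oxygen on an aromatic ring, gives a 1.2-fold higher number from compound 2 to compound 3 (0.09 log units; within the scatter) in this assay, so a second lengthening also stays inside the scatter. Even the two added carbons together give a 1.5-fold higher number from compound 1 to compound 3 (0.17 log units; within the scatter), which means that compound 1, compound 2 and compound 3 cannot be told apart here. Nothing measured offers an explanation for this. As far as these compounds go, a much shorter or much longer chain remains open, and so does a carboxylic acid or an amine in place of the hydroxyl of the 2-hydroxyethyl group.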